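Working notes: from compound 2 to compound 4

This account rests on a few compounds, and the source may have more. Where it says the series, first, only, none or still open, it means among the compounds named here.

Measured so far in a functional assay on the whole organism (strain Wistar albino) for inhibition, with Rattus norvegicus as the target, read by paw edema, with stated times of 1 h and 2 h, at a dose of 0.32 mmol/kg by the intraperitoneal route; on this read-out lower numbers stand for less inhibition and higher numbers for more inhibition at the one dose given (going by the name of the read-out):
- compound 1 `Cc1ccc(-c2nn(-c3ccc(Cl)cc3)cc2-c2cc(-c3ccc(Cl)cc3)[nH]c2-c2ccc(F)cc2)cc1` gives 38.3%
- compound 2 `COc1ccc(-c2[nH]c(-c3ccc(Cl)cc3)cc2-c2cn(-c3ccc(Cl)cc3)nc2-c2ccc(C)cc2)cc1` gives 9.38%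
- compound 3 `COc1ccc(-c2nn(-c3ccc(Cl)cc3)cc2-c2cc(-c3ccc(Cl)cc3)[nH]c2-c2ccc(OC)cc2)cc1` gives 10.5%

Compound 2 has the lowest of the three numbers. Its nearest neighbour is compound 3, separated by a number 1.1 percentage points higher from compound 2 to compound 3 (within the scatter), so the two cannot be told apart. Compound 1 stands furthest away, the step being a number 28.9 percentage points lower from compound 1 to compound 2 (beyond the scatter).

Compound 4 `COc1ccc(-c2[nH]c(-c3ccc(Cl)cc3)cc2-c2cn(-c3ccc(S(N)(=O)=O)cc3)nc2-c2ccc(C)cc2)cc1` differs from compound 2 in one place: sulfamoyl in place of chloro on an aromatic carbon. Cut one bond further out this reads 4-chlorophenyl to 4-sulfamoylphenyl. Neither measured step touches this ring; both concern the methoxy, fluoro and methyl groups on other rings, so nothing measured bears on the change. No direction can be derived from the data, and the most that can be said is that the step is expected to be small or none beyond the scatter, with wide uncertainty.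

Compound 4 is therefore estimated at 20%, within 5% to 45%, which means an expected step of a number 10.6 percentage points higher from compound 2 to compound 4 (beyond the scatter).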

Compound 4, a percentage reported as inhibition, in the whole organism at one dose (the size of the read-out at that dose, not a potency): 49.7%
The estimate for compound 4 lay 29.7 percentage points below the measured number, outside the stated range (above it).
By their numbers in this assay, from the lowest: compounds 2 and 3 (each within the scatter of the next); then compound 1; then compound 4.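

Among these compounds, the 4-chlorophenyl position, untouched by the earlier steps, turns out to matter for the read-out: in this assay, sulfamoyl in place of chloro on this aromatic carbon gives a number 40.3 percentage points higher from compound 2 to compound 4 (beyond the scatter), a large step. The change replaces a single chlorine with a group of four heavy atoms that brings a hydrogen-bond donor and hydrogen-bond acceptors, but one pair cannot show which of these features carries the step. No measurement at hand accounts for the size of this step.

As far as these compounds go, it remains open whether the step is specific to sulfamoyl or would also appear with another group here, such as methylsulfonyl, a carboxylic acid or an amine. From the compounds shown here alone, it is also open whether the same replacement would give a step of similar size on the core of compound 1 or compound 3.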